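Chloro for methyl on the weak aroyl end

The source may hold more compounds than are shown below. What is called first, only, known or untested is meant among the compounds shown, and "the series" means these compounds.

In a functional assay on OVCAR-3 cells (Homo sapiens) for antiproliferative activity, read by MTT assay, with a stated time of 24 h (a higher number here means a weaker inhibitor, a lower number a stronger inhibitor), compound 3 `Cc1ccccc1C(=O)NNC(=O)c1cccc(NS(=O)(=O)c2cnc(O)nc2O)c1` gives only a limit, > 20000 nM. Compound 1 `O=C(NNc1ccccc1Cl)c1cccc(NS(=O)(=O)c2cnc(O)nc2O)c1` gives 3350 nM and compound 2 `O=C(NNc1cccc(Cl)c1)c1cccc(NS(=O)(=O)c2cnc(O)nc2O)c1` gives 8040 nM, so both have real numbers. Compound 4 `O=C(NNC(=O)c1ccccc1Cl)c1cccc(NS(=O)(=O)c2cnc(O)nc2O)c1` differs from compound 3 in one place: chloro in place of methyl on an aromatic carbon. This is chloro in place of methyl on an aromatic carbon, ortho to a large group.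

For the measured compounds named here, no measured step shows this exact swap. The nearest evidence is on the amine nitrogen, where (2-methylphenyl)carbonyl replacing a chlorophenyl group gave an at least 5.9-fold higher number from compound 1 to compound 3 (0.77 log units; beyond the scatter) and an at least 2.4-fold higher number from compound 2 to compound 3 (0.39 log units; beyond the scatter). Exchanging one chlorophenyl group for the other gave a 2.4-fold higher number from compound 1 to compound 2 (0.38 log units; beyond the scatter). Compound 4 keeps the carbonyl of compound 3, so the gap in an at least 5.9-fold higher number from compound 1 to compound 3 (0.77 log units; beyond the scatter) is not expected to close, and only a small shift towards a lower number in this assay is expected. The expected size is an at least 1.2-fold lower number from compound 3 to compound 4 (0.09 log units; that floor lies within the scatter), and this may not exceed the scatter. For compound 4 the estimated value is 16000 nM, with an expected range of 6000 nM to 40000 nM.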

Compound 4, half-maximal inhibitory concentration: 7300 nM
Beside the measured number, compound 4's estimate is 2.2-fold (0.34 log units) above it; the range from low to high includes it.
By their numbers in this assay, from the lowest: compound 1; then compounds 4 and 2 (each within the scatter of the next). At a limit, above all of these: compound 3.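

Working notes: in this assay the aroyl end is not weak as such, since chloro in place of methyl on an aromatic carbon, ortho to a large group, gives an at least 2.7-fold lower number from compound 3 to compound 4 (0.43 log units; beyond the scatter). Compound 3 gives > 20000 nM, which is a limit and not a number: the limit of > 20000 nM in this assay, at which 1 of the 4 values shown sits. With chloro in this place the carbonyl link still costs something against the direct link, with a 2.2-fold higher number from compound 1 to compound 4 (0.34 log units; beyond the scatter), yet compound 4 cannot be told from the 3-chlorophenyl analogue, with a 1.1-fold lower number from compound 2 to compound 4 (0.04 log units; within the scatter).

On these data alone, whether the gain belongs to chloro in particular stays open, as does what a fluoro or methoxy group would give on this same carbon. Also open, as far as these compounds go, is how a chloro group elsewhere on the aroyl ring would compare, as in a (3-chlorophenyl)carbonyl end.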